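Replacing the sulfur-linked benzoxazole with a piperazine side chain

The source may report more compounds than this note shows. Statements on the series, on what has been measured and on what is new or still open speak of the compounds shown alone.

Measured compounds:
Compound 1 `Cn1c(-c2ccc(NC(=O)CSc3nc4ccccc4o3)cc2)nc(-c2ccccc2)c1-c1ccccc1`: 56%
Compound 2 `Cc1ccc2oc(SCC(=O)Nc3ccc(-c4nc(-c5ccccc5)c(-c5ccccc5)n4C)cc3)nc2c1`: 40.3%
Compound 3 `Cn1cnnc1SCC(=O)Nc1ccc(-c2nc(-c3ccccc3)c(-c3ccccc3)n2C)cc1`: 61.2%

Of the compounds shown here, three sharing the same core have been measured in a functional assay on MCF7 cells (Homo sapiens) for cytotoxicity, read by MTT assay, with a stated time of 24 h, tested at 16 ug/mL; a lower number here means a weaker effect, a higher number a stronger effect of the compound at the concentration tested. Compound 1 gives 56%, which places it in the middle of the three numbers: compound 3 sits within the scatter of it, while compound 2 lies clearly lower, as the step of a number 15.7 percentage points lower from compound 1 to compound 2 (beyond the scatter) shows. The step of a number 5.2 percentage points higher from compound 1 to compound 3 (within the scatter) shows that exchanging the group on the sulfur left the read-out essentially unchanged, and the step of a number 20.9 percentage points higher from compound 2 to compound 3 (beyond the scatter) shows a modest gain.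

Compound 4 `CN(C)/C=C/N1CCN(CC(=O)Nc2ccc(-c3nc(-c4ccccc4)c(-c4ccccc4)n3C)cc2)CC1` has not yet been measured. Compared with compound 1, the change is 4-(2-(dimethylamino)ethenyl)piperazin-1-yl in place of (1,3-benzoxazol-2-yl)sulfanyl on a saturated chain carbon bound to a carbonyl carbon. Going by the values given here, none of the measured steps covers this change directly: all three keep the sulfur and alter only the ring on it or a methyl on that ring, and those alterations moved the read-out by modest amounts at most. The change to compound 4 removes the sulfur and the aromatic ring system altogether, so the measured steps give only weak guidance, and a wide range is appropriate.

On that basis compound 4 is expected to give about 50%, somewhere between 25% and 72%. This estimate means a step of a number 6 percentage points lower from compound 1 to compound 4 (within the scatter), expected to stay within the scatter.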

Compound 4, a percentage reported as activity, at one concentration (the size of the read-out at that concentration, not a potency): 19.4%
The estimate for compound 4 lay 30.6 percentage points above the measured number; measured number outside the range, below it.
By their numbers in this assay, from the lowest: compound 4; then compound 2; then compounds 1 and 3 (each within the scatter of the next).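

In this assay, changing the ring on the sulfur had moved the read-out only modestly at most, but replacing the whole sulfur-linked group on the saturated chain carbon bound to a carbonyl carbon has a much larger effect, with a number 36.6 percentage points lower from compound 1 to compound 4 (beyond the scatter) and a number 41.8 percentage points lower from compound 3 to compound 4 (beyond the scatter). Even the weakest sulfur-linked compound keeps a clear margin, with a number 20.9 percentage points lower from compound 2 to compound 4 (beyond the scatter), so compound 4 has the weakest effect of the four and this position is far less tolerant of a large change than the ring swaps suggested. Nothing available explains this loss of effect.

This single change removes the sulfur and the aromatic ring system and adds both a piperazine and a 2-(dimethylamino)ethenyl group, so the compounds shown cannot say which of these alterations accounts for the drop. A plain piperazin-1-yl without the ethenyl group, or a 4-methylpiperazin-1-yl, would help separate the effect of the ring from that of its side chain, while a benzoxazole joined through a carbon chain would test the sulfur on its own.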